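A few compounds are considered here, and "the series" means these few. Any claim that something is new, unique, unknown or untested is made for them only; others in the source may bear on it.

Measured so far:
compound 1 `O=c1c(CSc2cc(=O)c3ccccc3s2)coc2ccccc12` — 2800 nM
compound 2 `Cc1cc(C)n2nc(SCc3nnc(SCc4coc5ccccc5c4=O)n3N)nc2n1` — 1900 nM

Both have been run in a functional assay on LM7 cells (Homo sapiens) for cytotoxicity, read by MTT assay, with a stated time of 72 h; a higher number here means a weaker inhibitor, a lower number a stronger inhibitor. In this assay compound 1 gives 2800 nM, and compound 2 gives 1900 nM. These two numbers fall within the usual scatter of each other, so compound 2 does not separate from compound 1 on the evidence in hand. For the measured compounds named here, no pair of measured compounds differs in a single place, so no single-change step has yet been measured.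

Compound 3 `Cc1cc(C)n2nc(SCc3nnc(SCc4coc5ccccc5c4=O)n3-c3ccccc3)nc2n1` is the next one to be measured in this assay. It differs from compound 2 by phenyl in place of amino on an aromatic nitrogen. Going by the values given here, with no measured step to lean on, only a small movement is expected, in either direction, not beyond the scatter. The step expected is a 1.1-fold lower number from compound 2 to compound 3 (0.02 log units; within the scatter). In this assay compound 3 is expected to give about 1800 nM, with a range of 700 nM to 4500 nM.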

Compound 3, half-maximal inhibitory concentration: 16600 nM
Compound 3: middle estimate off by 9.2-fold (0.96 log units), on the low side; the measured number lies above the stated range.
By their numbers in this assay, from the lowest: compounds 2 and 1 (each within the scatter of the next); then compound 3.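

In this assay phenyl in place of amino on the aromatic nitrogen gives an 8.7-fold higher number from compound 2 to compound 3 (0.94 log units; beyond the scatter) and so marks this place as sensitive to substitution, which compound 1 and compound 2 alone could not show. For the compounds shown here, the single change swaps one nitrogen atom, counted as a hydrogen-bond donor and acceptor, for six carbon atoms in an aromatic ring with neither, so ring, size and donor count all change together. Nothing measured here bears on the reason for this step.

From the compounds shown here alone, it remains open whether the higher number goes with the arrival of the phenyl ring or with the departure of the amino group. A methyl group, a benzyl group or a dimethylamino group on this nitrogen would pull these apart.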